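Swapping 4-(trifluoromethyl)phenyl for 2-fluorophenyl on the shared core

The compounds below may be only part of what the source reports. "The series", "measured", "known", "first", "only" and "open" are said of these compounds alone.

In a functional assay on WM 266-4 cells (Homo sapiens) for antiproliferative activity, read by MTT assay, with a stated time of 24 h (a lower number here means a stronger inhibitor of growth, a higher number a weaker inhibitor of growth), compound 1 `c1ccc(COc2ccc(C3CC(c4ccc5c(c4)OCCO5)=NN3c3ccccc3)cc2)cc1` gives 1130 nM and compound 3 `c1ccc(COc2cccc(C3CC(c4ccc5c(c4)OCCO5)=NN3c3ccccc3)c2)cc1`, which also carries benzyloxy, gives 870 nM as its result, two values within the usual scatter of each other. Compound 2 `FC(F)(F)c1ccc(C2CC(c3ccc4c(c3)OCCO4)=NN2c2ccccc2)cc1` is reported as > 100000 nM and that is a limit of the assay, not a number. Compound 2 therefore stands at the limit of > 100000 nM in this assay, at which 1 of the 3 values shown sits, and has no firmer figure. Going by the values given here, the only measured step with a single change is an at least 88-fold higher number from compound 1 to compound 2 (1.94 log units; beyond the scatter) and it is large, with trifluoromethyl in place of benzyloxy on an aromatic carbon.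

Compound 4 `Fc1ccccc1C1CC(c2ccc3c(c2)OCCO3)=NN1c1ccccc1` has not yet been measured. Its difference from compound 2 is this: 2-fluorophenyl in place of 4-(trifluoromethyl)phenyl on a saturated ring carbon and so 2-fluorophenyl stands in place of 4-(trifluoromethyl)phenyl on a saturated ring carbon. Compound 4 has no benzyloxy either, so the step of an at least 88-fold higher number from compound 1 to compound 2 (1.94 log units; beyond the scatter) gives no ground to expect a return to the level of compound 1. A modest move towards a lower number, meaning a stronger inhibitor of growth, is still expected, and the estimate is an at least 4.0-fold lower number from compound 2 to compound 4 (0.60 log units; beyond the scatter) with much uncertainty. For compound 4 the estimated value is 25000 nM with an expected range from 4000 nM to 100000 nM and a result at the limit would be no surprise.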

Compound 4, concentration for 50% growth inhibition: 9120 nM
The estimate for compound 4 lay 2.7-fold (0.44 log units) above the measured number, within the range that was stated.
By their numbers in this assay, from the lowest: compounds 3 and 1 (each within the scatter of the next); then compound 4. At a limit, above all of these: compound 2.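

Compound 2 is held at a limit of the assay, not a number: the limit of > 100000 nM in this assay, at which 1 of the 4 values shown sits.

Against that limit, placing 2-fluorophenyl in place of 4-(trifluoromethyl)phenyl on the saturated ring carbon gives an at least 10-fold lower number from compound 2 to compound 4 (1.04 log units; beyond the scatter) in this assay, so this change is large even though the true size of the step stays open on one side. Going by these compounds alone, until now, the only compounds with firm numbers carried benzyloxy. Compound 4 has no benzyloxy and still gives a firm number, so a firm number here does not require benzyloxy. Even so, compound 4 gives 9120 nM, a higher number than compound 1 at 1130 nM.

The compounds shown cannot separate the part played by the fluorine from the part played by the loss of trifluoromethyl, since the two groups differ in both respects and only one fluorinated ring gives a firm number here. Going by these compounds, whether a plain phenyl group, or a ring bearing an amine or a carboxylic acid, would fall nearer compound 4 or nearer compound 1 at this position remains open.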